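Thiazole for methyloxazole in the sulfonamide series

The source may hold more compounds than are shown below. What is called first, only, known or untested is meant among the compounds shown, and "the series" means these compounds.

Compound 1 `O=S(=O)(Nc1nccs1)c1ccc2c(c1)OCC[C@H]2c1ccc(C(F)(F)F)cc1-c1ccc(F)nc1` has in a physicochemical assay for lipophilicity (a higher number here means a more lipophilic compound, a lower number a more polar compound), the entry "not determined" (no result reported), so no result for it. Among the compounds with values here, compound 2 `Cc1nc(-c2cc(C(F)(F)F)ccc2[C@@H]2CCOc3cc(S(=O)(=O)Nc4nccs4)ccc32)co1` gives 2.9 in this assay, the only figure so far. Compound 3 `O=S(=O)(Nc1nccs1)c1ccc2c(c1)OCC[C@H]2c1ccc(C(F)(F)F)cc1-c1nccs1` awaits measurement. Its structure differs from compound 2 by 1,3-thiazol-2-yl in place of 2-methyl-1,3-oxazol-4-yl on an aromatic carbon. Within the data shown here, no step between two measured compounds is available, so the size of the change rests on the structural difference alone: a small shift at most, probably none beyond the usual scatter, if anything slightly upward. For compound 3 the expected value in this assay is 3, with a range from 2.6 to 3.4. The step this estimate means is expected to be a number 0.10 log units higher from compound 2 to compound 3 (within the scatter).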

Compound 3, distribution coefficient: 3.3
Compound 3: the middle estimate sits 0.30 log units below what was measured; the measured number falls inside the stated range.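

In this assay, within the data shown here, 1,3-thiazol-2-yl in place of 2-methyl-1,3-oxazol-4-yl gives a number 0.40 log units higher from compound 2 to compound 3 (beyond the scatter), the first readable step at this aromatic carbon. Among these compounds, the read-out at this position therefore responds to an exchange of one five-membered aromatic ring for another, although the step is only one pair. No available evidence bears on the origin of this step.

Steps to compound 1 cannot be read, as it has no number. Open, on these data alone, is whether the methyl or the ring atoms carry the step, which a 2-methyl-1,3-thiazol-4-yl group would separate, and how an amine or a carboxylic acid would read here.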